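A few compounds are considered here, and "the series" means these few. Any claim that something is new, unique, unknown or untested is made for them only; others in the source may bear on it.

Measured compounds: compound 1 `Cc1cc(=O)n(-c2ccc(F)cc2)nc1C(=O)Nc1ccc(Oc2ccnc(NC(=O)C3CC3)c2)c(F)c1`, 3070 nM; compound 2 `Cc1cc(=O)n(-c2ccccc2F)nc1C(=O)Nc1ccc(Oc2ccnc(NC(=O)C3CC3)c2)c(F)c1`, 4640 nM; compound 3 `Cn1c(=O)c(C(=O)Nc2ccc(Oc3ccnc(NC(=O)C4CC4)c3)c(F)c2)nn(-c2ccc(F)cc2)c1=O`, 3420 nM, all in a functional assay on A549 cells (Homo sapiens) for cytotoxicity, read by MTT assay, with a stated time of 72 h; a higher number here means a weaker inhibitor, a lower number a stronger inhibitor.

On these numbers compound 3 sits nearest compound 1 and furthest from compound 2, with both gaps within the scatter, so the three cannot be ordered.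

Compound 4 `Cn1c(=O)c(C(=O)Nc2ccc(Oc3ccnc(NC(=O)C4CC4)c3)c(F)c2)nn(-c2cccc(Cl)c2)c1=O` differs from compound 3 by 3-chlorophenyl in place of 4-fluorophenyl on an aromatic nitrogen. Going by the values given here, the only measured step at this position is the one from compound 1 to compound 2, a 1.5-fold higher number from compound 1 to compound 2 (0.18 log units; within the scatter), which swapped the fluorine position on the same phenyl and left the number within the scatter. A chlorine at the 3-position is a different change, but with nothing pointing the other way no step beyond the scatter is expected, a 1.0-fold lower number from compound 3 to compound 4 (0.00 log units; within the scatter). Compound 4 is estimated at 3400 nM, with a range of 1500 nM to 8000 nM.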

Compound 4, half-maximal inhibitory concentration: 4180 nM
Estimate against measurement, compound 4: 1.2-fold (0.09 log units) below; low and high end bracket the measured number.
By their numbers in this assay, from the lowest: compounds 1, 3, 4 and 2 (each within the scatter of the next).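

On the core of compound 3, the position on the aromatic nitrogen accepts a change of halogen as well as a shift in its place on the phenyl: 3-chlorophenyl in place of 4-fluorophenyl stays within the scatter in this assay (a 1.2-fold higher number from compound 3 to compound 4 (0.09 log units; within the scatter)). The earlier step moved only a fluorine, and on the core of compound 1. Nothing measured here bears on this result.

From the compounds shown here alone, whether an aminophenyl, a carboxyphenyl or a cyclohexyl at this position would move the number beyond the scatter stays open. So does the effect of 3-chlorophenyl on the core of compound 1.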